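The source may hold more compounds than are shown below. What is called first, only, known or untested is meant among the compounds shown, and "the series" means these compounds.

The measured compounds in an assay on HEK293F cells for inhibition of AP2-associated protein kinase 1 (Homo sapiens), read by Western blot, with a stated time of 3 h; a lower number here means a stronger inhibitor, a higher number a weaker inhibitor:
compound 1 `CC(=O)Nc1cc(-c2ccc(OC[C@@](C)(N)CC(C)C)c(F)c2)ccn1` gives 3.7 nM;
compound 2 `CC(=O)Nc1cc(-c2ccc(OC[C@@H](N)CC(C)C)c(F)c2)ccn1` gives 1.6 nM;
compound 3 `COC(=O)Nc1cc(-c2cnc(OC[C@@](C)(N)CC(C)C)c(Cl)c2)ccn1` gives 4.2 nM.

Compound 2 stands as the strongest inhibitor of the three in this assay: compound 1 and compound 3 both sit higher by a margin beyond the scatter. Among the measured compounds shown here, the single one-place step among the measured compounds, a 2.3-fold lower number from compound 1 to compound 2 (0.36 log units; beyond the scatter), concerns the amine-bearing chain and not the aromatic ring. Compound 4 `CC(=O)Nc1cc(-c2ccc(OC[C@@H](N)CC(C)C)c(C)c2)ccn1` differs from compound 2 in one place: methyl in place of fluoro on an aromatic carbon. For the measured compounds named here, no measured pair isolates this change. Compound 3 carries a chloro group but differs from compound 2 in more than one place at once, so its value says little about the swap on its own. Going by the values given here, with no step bearing directly on the change, the expectation is that compound 4 stays close to compound 2, with no movement beyond the scatter in either direction. Compound 4 is therefore estimated at 2.5 nM, within a range of 0.8 nM to 8 nM. For compound 4 this means an expected step of a 1.6-fold higher number from compound 2 to compound 4 (0.19 log units; within the scatter).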

Compound 4, half-maximal inhibitory concentration: 1.1 nM
Estimate against measurement, compound 4: 2.3-fold (0.36 log units) above; measured number inside the range.
By their numbers in this assay, from the lowest: compounds 4 and 2 (each within the scatter of the next); then compounds 1 and 3 (each within the scatter of the next).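

In this assay, placing methyl instead of fluoro on the aromatic carbon ortho to a (2-amino-4-methylpentyl)oxy group gives a 1.5-fold lower number from compound 2 to compound 4 (0.16 log units; within the scatter) and so stays within the scatter. Among the compounds shown here, this is the first direct reading at this position: the only earlier one-place step lay on the amine-bearing chain, and the chloro of compound 3 came with other differences. Here a carbon group replaces a halogen without a change beyond the scatter, though nothing measured bears on the reason for this result.

As far as these compounds go, whether ethyl, methoxy or a nitrile at this position would read the same as methyl and fluoro remains open. From the compounds shown here alone, it is also open whether methyl would behave alike on the chain of compound 1 or with the methyl carbamate of compound 3.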